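A few compounds are considered here, and "the series" means these few. Any claim that something is new, unique, unknown or untested is made for them only; others in the source may bear on it.

Compound 2 `COc1ccc(C2=NN(C(=O)c3ccc(Cl)nc3)C(c3ccc(Br)cc3)C2)cc1` gives 7130 nM in a functional assay on WM 266-4 cells (Homo sapiens) for antiproliferative activity, read by MTT assay, with a stated time of 24 h (a higher number here means a weaker inhibitor of growth, a lower number a stronger inhibitor of growth), the second highest of the three numbers in hand. Compound 1 `COc1ccc(C2=NN(C(=O)c3ccc(Cl)nc3)C(c3ccc(Cl)cc3)C2)cc1` gives 1450 nM in this assay, and compound 3 `COc1ccc(C2=NN(C(=O)c3ccc(C)nc3Cl)C(c3ccc(Br)cc3)C2)cc1` gives 8470 nM. Compound 4 `COc1ccc(C2=NN(C(=O)c3ccc(Cl)nc3)C(c3ccc(OCc4ccccc4)cc3)C2)cc1` differs from compound 2 by benzyloxy in place of bromo on an aromatic carbon. Among the measured compounds shown here, no measured step alters this position in the same way. For the measured compounds named here, the nearest precedent is a 4.9-fold higher number from compound 1 to compound 2 (0.69 log units; beyond the scatter), which shows that a change at this carbon can move the number; the acyl change in a 1.2-fold higher number from compound 2 to compound 3 (0.07 log units; within the scatter) lies within the scatter. Going by the values given here, with no closer precedent, the expected step of a 1.2-fold lower number from compound 2 to compound 4 (0.07 log units; within the scatter) in this assay is treated as small and uncertain in direction. Compound 4 is therefore estimated at 6000 nM, with a range of 2000 nM to 20000 nM.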

Compound 4, concentration for 50% growth inhibition: 10600 nM
Estimate against measurement, compound 4: 1.8-fold (0.25 log units) below, within the range that was stated.
By their numbers in this assay, from the lowest: compound 1; then compounds 2, 3 and 4 (each within the scatter of the next).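

In this assay the step of a 1.5-fold higher number from compound 2 to compound 4 (0.17 log units; within the scatter) shows that benzyloxy, with 8 heavy atoms and an added aromatic ring, is tolerated on this aromatic carbon as well as the single atom of bromo. Against chloro the same change gives a 7.3-fold higher number from compound 1 to compound 4 (0.86 log units; beyond the scatter) so that, among these three groups at this place, only chloro in compound 1 stands apart. No measured evidence here explains that separation.

An amine, a carboxylic acid or fluoro at this carbon could fall on either side. On these data alone, whether chloro keeps its lower number with the 2-chloro-6-methylpyridin-3-yl acyl group also remains open.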